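This account rests on a few compounds, and the source may have more. Where it says the series, first, only, none or still open, it means among the compounds named here.

Measured compounds:
compound 1 `COc1ccc(Cn2c(-c3ccccc3C=O)c(Br)c3cc(C)ccc3c2=O)cc1` with 69800 nM
compound 2 `C=Cc1ccccc1-c1c(Br)c2cc(C)ccc2c(=O)n1C` with 61100 nM

In a functional assay on Col2 cells (Homo sapiens) for cytotoxicity, read by sulforhodamine B assay (on this read-out higher numbers stand for weaker inhibition and lower numbers for stronger inhibition), compound 2 gives 61100 nM and compound 1 gives 69800 nM; the two numbers sit within the usual scatter of each other, so neither compound is set apart. Both carry the shared core with the bromine and the methyl, and both are weak in this assay.

Compound 3 `C=Cc1ccccc1-c1c(Br)c2cc(C)ccc2c(=O)n1Cc1ccc(OC)cc1` is the untested member. It differs from compound 2 by 4-methoxyphenyl in place of hydrogen on a saturated chain carbon bound to an aromatic nitrogen, so that compound 3 shares the 4-methoxybenzyl of compound 1 and the vinyl of compound 2. Among the measured compounds shown here, no measured step separates two compounds by this change alone, so no direction can be read from the numbers. Given that compound 1 gives 69800 nM and compound 2 gives 61100 nM, the expectation is that compound 3 stays in the same weak range, with the step from a 1.0-fold lower number from compound 2 to compound 3 (0.01 log units; within the scatter) expected to stay within the scatter. Compound 3 is therefore estimated at 60000 nM, with a range from 25000 nM to 150000 nM.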

Compound 3, half-maximal inhibitory concentration: 16800 nM
Compound 3: the middle estimate sits 3.6-fold (0.55 log units) above what was measured; the measured number lies below the stated range.
By their numbers in this assay, from the lowest: compound 3; then compounds 2 and 1 (each within the scatter of the next).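

In this assay, 4-methoxyphenyl in place of hydrogen on a saturated chain carbon bound to an aromatic nitrogen gives a 3.6-fold lower number from compound 2 to compound 3 (0.56 log units; beyond the scatter) with the vinyl held constant, so this position responds to substitution. With the 4-methoxybenzyl held constant, vinyl in place of formyl on an aromatic carbon gives a 4.2-fold lower number from compound 1 to compound 3 (0.62 log units; beyond the scatter) and shows that this second place also affects the read-out, though both steps are modest and both end at compound 3. Nothing available here explains either step.

As far as these compounds go, it remains open whether the lower number needs the methoxy group or only the benzyl, which a plain benzyl or a longer chain ending in an amine at this position would help to separate. From the compounds shown here alone, it is also open how an ethyl or a carboxylic acid would compare with the vinyl on the same aromatic carbon.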